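Hydroxy for Ethyl on the Core of Compound 1

This account rests on a few compounds, and the source may have more. Where it says the series, first, only, none or still open, it means among the compounds named here.

Of the compounds shown here, three have been measured in a functional assay (spleen, spleen) for activation, with Mus musculus as the target; on this read-out higher numbers stand for an effect only at larger amounts of compound and lower numbers for an effect already at smaller amounts. Compound 1, with structure `CCc1nc(N)c2nc(O)n(Cc3ccccc3)c2n1`, gives 1 uM in this assay and stands lowest of the three numbers. Compound 2, with structure `COc1cccc(Cn2c(O)nc3c(N)ncnc32)c1`, gives 10 uM, and compound 3, with structure `COc1ccccc1Cn1c(O)nc2c(N)ncnc21`, gives 10 uM; each of these two values lies a full step above that of compound 1, beyond the scatter, though compound 2 and compound 3 differ from compound 1 in more than one place, so none of these pairs forms a single clean step.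

The compound not yet measured is compound 4, with structure `Nc1nc(O)nc2c1nc(O)n2Cc1ccccc1`. It differs from compound 1 as follows: hydroxy in place of ethyl on an aromatic carbon. Among the compounds with values here, compound 2 and compound 3, both without the ethyl group, sit higher than compound 1 in this assay, which is the only guide available here. On that basis compound 4 is expected to move upward, and the step from compound 1 to compound 4 is estimated as a 10-fold higher number from compound 1 to compound 4 (1.00 log units; beyond the scatter). Compound 4 is therefore expected to give about 10 uM in this assay, with a range from 2 uM to 50 uM.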

Compound 4, minimum effective concentration: 0.1 uM
For compound 4 the middle estimate is 100-fold (2.00 log units) above the measured one; the whole stated range lies above it.
By their numbers in this assay, from the lowest: compound 4; then compound 1; then compounds 2 and 3 (each within the scatter of the next).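

In this assay, within the data shown here, putting hydroxy in place of ethyl on the aromatic carbon between two ring nitrogen atoms gives a 10-fold lower number from compound 1 to compound 4 (1.00 log units; beyond the scatter), the first step in this set that can be read at a single place. It shows that the ethyl group is not needed at this position for an effect at small amounts of compound, since the change removes that two-carbon group and the number still falls. Among these compounds, with the benzyl group and the amino group left unchanged, this step can be assigned to this one position on the core, which the earlier compounds, differing from compound 1 in more than one place, could not do. Nothing given here explains why hydroxy at this position goes with the lower number.

The compounds shown leave open how other groups on this same carbon would read out, such as a methoxy group, a methylamino group, a carboxylic acid or a longer chain like butyl. They also leave open whether the step from ethyl to hydroxy would be of similar size with a methoxy group on the benzyl ring, as carried by compound 2 and compound 3.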